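The source may hold more compounds than are shown below. What is called first, only, known or untested is meant among the compounds shown, and "the series" means these compounds.

Working notes on the series. The shared core carries a 4-substituted phenyl on a five-membered heteroaromatic ring, with an exocyclic imine to a second small ring bearing a carbonyl. Compound 1 `Cc1ccc(-c2cc(/N=C3/NC(=O)CS3)cs2)cc1` lacks the arylidene arm on that second ring. In a functional assay on MDA-MB-231 cells (Homo sapiens) for cytotoxicity, read by MTT assay, with a stated time of 72 h (on this read-out lower numbers stand for stronger inhibition and higher numbers for weaker inhibition), compound 1 returns only a limit, > 50000 nM, so no number is available for it; this is recorded as the limit of > 50000 nM in this assay, at which 1 of the 2 values shown sits. Compound 2 `COc1ccc(/C=C2\S/C(=N\c3csc(-c4ccc(Cl)cc4)c3)NC2=O)cc1` adds the 4-methoxybenzylidene arm and a chlorine on the outer phenyl. In this assay compound 2 gives 1200 nM. For the measured compounds named here, compound 2 thus holds the only number in the set; the remaining value is a limit, so no step between measured compounds can be stated.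

Compound 3 `CN(C)c1ccc(/C=C2\S/C(=N\c3csc(-c4ccc(Cl)cc4)c3)NC2=O)cc1` is next. The change from compound 2 is dimethylamino in place of methoxy on an aromatic carbon. Going by the values given here, no measured step informs this change. The expectation is a step from compound 2 to compound 3 of a 1.2-fold lower number from compound 2 to compound 3 (0.08 log units; within the scatter) in this assay, a move that stays within the usual scatter rather than a clear gain or loss. On that basis compound 3 is estimated at 1000 nM in this assay, with a plausible range from 300 nM to 4000 nM.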

Compound 3, half-maximal inhibitory concentration: 800 nM
Compound 3: middle estimate off by 1.3-fold (0.10 log units), on the high side, within the range that was stated.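

Working notes on the step. In this assay, dimethylamino in place of methoxy on an aromatic carbon, para to a large group, gives a 1.5-fold lower number from compound 2 to compound 3 (0.18 log units; within the scatter). For the compounds shown here, this is the first step that can be read between two measured compounds, and it shows that 4-(dimethylamino)phenyl and 4-methoxyphenyl are not told apart by this read-out: the values of the pair lie within the usual scatter of each other, so neither group can be ranked over the other at this position. No measured property in the data available bears on this step, and the data offer no account of it.

Two compounds carrying groups with one hydrogen-bond acceptor each say nothing about whether the position accepts a group of another kind, such as a carboxylic acid, a primary amine or a longer alkoxy chain. The separate contributions of the 4-methoxybenzylidene arm and the chlorine on the outer phenyl also remain open, as no pair shown differs in only one of these places.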